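Changing the Amide Ring Without Losing Cell Tolerance

The source may report more compounds than this note shows. Statements on the series, on what has been measured and on what is new or still open speak of the compounds shown alone.

Of the compounds shown here, three have so far been tested in a toxicity assay on THP-1 cells (Homo sapiens) for inhibition; a higher number here means that more compound is tolerated, a lower number that less compound is tolerated. Compound 1, `Cn1c(-c2cccc(Cl)c2)cnc1NC(=O)c1ccc(F)cc1`, gives > 50000 nM, which is a limit of the assay rather than a measured number. Compound 2, `COc1ccc(CNC(=O)NC(=O)c2ccc(F)cc2)cc1`, likewise gives > 50000 nM, again only a limit. Compound 3, `COc1ccc(-c2cnc(NC(=O)c3cccnc3)n2C)cc1`, reaches > 100000 nM, also a limit. Compound 3 therefore stands at the limit of > 100000 nM in this assay, at which 1 of the 3 values shown sits, while the other two values sit at the limit of > 50000 nM in this assay, at which 2 of the 3 values shown sit; none of the three compounds showed a measurable cytotoxic concentration within the range tested.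

The next compound, compound 4, `COc1ccc(-c2cnc(NC(=O)c3ccc(Br)cc3)n2C)cc1`, differs from compound 3 in one place: 4-bromophenyl in place of pyridin-3-yl on a carbonyl carbon. The shared core is kept, and only the ring on the carbonyl carbon is exchanged.

Among the measured compounds shown here, no two measured compounds differ in just one place, so there is no measured step to lean on. All three values shown end at a limit, and the expectation for compound 4 is simply that it is tolerated up to a similarly high concentration. The step of an at least 1.6-fold lower number from compound 3 to compound 4 (0.22 log units; that floor lies within the scatter) is expected to be none beyond the usual scatter. Compound 4 is therefore estimated at 60000 nM, with a likely range from 20000 nM to 150000 nM.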

Compound 4, half-maximal cytotoxic concentration: > 100000 nM
Compound 4 ended at the assay's limit; the forecaster's own chance of this, stated with the estimate: 70%; middle value at least 1.6-fold (0.22 log units) away from the limit.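

Among the compounds shown here, compound 3 and compound 4 both end at a limit of the assay rather than at a measured number, so no step between them can be read. The compounds shown leave open whether exchanging pyridin-3-yl for 4-bromophenyl changes cell tolerance at all, and at what concentration, if any, these compounds harm the cells.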